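The source may report more compounds than this note shows. Statements on the series, on what has been measured and on what is new or still open speak of the compounds shown alone.

Measured compounds in a functional assay on A549 cells (Homo sapiens) for inhibition, read by CCK-8 assay, with a stated time of 48 h; on this read-out lower numbers stand for stronger inhibition and higher numbers for weaker inhibition:
- Compound 1, `COc1cc(-c2ccnc3cc(-c4ccc(Cl)cc4)nn23)cc(OC)c1OC`, gives 3070 nM.
- Compound 2, `COc1cc(-c2ccnc3cc(-c4ccc(C(C)(C)C)cc4)nn23)cc(OC)c1OC`, gives only a limit of the assay, > 10000 nM, where one of the three values sits (the limit of > 10000 nM in this assay, at which 1 of the 3 values shown sits).
- Compound 3, `COc1cc(-c2ccnc3cc(-c4ccc5ccn(C)c5c4)nn23)cc(OC)c1OC`, gives 829 nM.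

Among the two numbers, compound 1 holds the highest; its nearest neighbour is compound 3, with a 3.7-fold lower number from compound 1 to compound 3 (0.57 log units; beyond the scatter). Compound 4, `COc1cc(-c2ccnc3cc(-c4cccc(C#N)c4)nn23)cc(OC)c1OC`, differs from compound 1 in one place: 3-cyanophenyl in place of 4-chlorophenyl on an aromatic carbon.

For the measured compounds named here, three measured steps bear on this position. On the same aromatic carbon, an at least 3.2-fold higher number from compound 1 to compound 2 (0.51 log units; beyond the scatter), a 3.7-fold lower number from compound 1 to compound 3 (0.57 log units; beyond the scatter) and an at least 12-fold lower number from compound 2 to compound 3 (1.08 log units; beyond the scatter). Going by the values given here, none of these steps puts a 3-cyanophenyl in place of a 4-chlorophenyl, so no measured step speaks directly for compound 4. The aryl group at this position plainly matters, yet the steps run both ways and give no direction for the new group. Compound 4 is therefore expected to sit close to compound 1, with a 1.0-fold lower number from compound 1 to compound 4 (0.01 log units; within the scatter), not beyond the scatter. The estimate for compound 4 in this assay is 3000 nM, expected to fall between 1000 nM and 10000 nM.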

Compound 4, half-maximal inhibitory concentration: > 10000 nM
Compound 4: no number, only a limit (the forecaster's own chance of this, stated with the estimate: 20%); middle value at least 3.3-fold (0.52 log units) away from the limit.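

In this assay compound 4 joins compound 2 at the limit, so that 3-cyanophenyl and 4-(tert-butyl)phenyl, two quite different groups, both give a limit and not a number: the limit of > 10000 nM in this assay, at which 2 of the 4 values shown sit. Replacing 4-chlorophenyl with 3-cyanophenyl weakens inhibition, with an at least 3.2-fold higher number from compound 1 to compound 4 (0.51 log units; beyond the scatter), and the gap to the 1-methyl-1H-indol-6-yl group is wider, with an at least 12-fold higher number from compound 3 to compound 4 (1.08 log units; beyond the scatter). Among the four compounds, then, a second phenyl substituent can also cost activity at this aromatic carbon, while the step between the two compounds at the limit cannot be read.

Going by these compounds, whether the loss belongs to the nitrile itself or to its placing on the ring stays open; a 4-cyanophenyl or a 3-chlorophenyl group would separate the two. How an amine or a carboxylic acid on the phenyl ring would read in this assay is open as well.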